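Indolecarboxamides on an arylpiperazine propyl chain: antagonist binding

The source may report more compounds than this note shows. Statements on the series, on what has been measured and on what is new or still open speak of the compounds shown alone.

Measured so far:
compound 1, `COc1ccccc1N1CCN(CCCNC(=O)c2ccc3[nH]ccc3c2)CC1`: 11.8 nM
compound 2, `COc1ccccc1N1CCN(CCCNC(=O)Cc2c[nH]c3ccccc23)CC1`: 5.25 nM

In an assay on isolated protein (thoracic aorta, strain Sprague-Dawley) for antagonist activity at Alpha-1D adrenergic receptor (Rattus norvegicus), with a stated time of 20 min (a higher number here means weaker binding, a lower number tighter binding), compound 1 gives 11.8 nM, the highest of the two numbers; its nearest neighbour is compound 2 with 5.25 nM. Going by the values given here, the one measured step, a 2.2-fold lower number from compound 1 to compound 2 (0.35 log units; beyond the scatter), comes from putting (1H-indol-3-yl)methyl in place of 1H-indol-5-yl on the carbonyl carbon.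

Compound 3, `COc1ccccc1N1CCN(CCCNC(=O)c2cn(C)c3ccccc23)CC1`, is not yet measured. It differs from compound 1 by 1-methyl-1H-indol-3-yl in place of 1H-indol-5-yl on a carbonyl carbon. The step from compound 1 to compound 2 bears on this only in part, as it also changes the point of attachment of the indole to the carbonyl carbon, while compound 3 adds a methyl on the indole nitrogen and has no methylene spacer. Among the compounds with values here, no measured step covers that methyl. Given that compound 1 to compound 2 was modest, compound 3 is expected to sit near compound 1, with a 1.4-fold lower number from compound 1 to compound 3 (0.14 log units; within the scatter), and to give 8.5 nM (range 3 nM to 25 nM).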

Compound 3, dissociation constant: 5.5 nM
Compound 3: middle estimate off by 1.5-fold (0.19 log units), on the high side; measured number inside the range.
By their numbers in this assay, from the lowest: compounds 2 and 3 (each within the scatter of the next); then compound 1.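

In this assay, 1-methyl-1H-indol-3-yl in place of 1H-indol-5-yl on the carbonyl carbon gives a 2.1-fold lower number from compound 1 to compound 3 (0.33 log units; beyond the scatter), even though the entering group has 0 hydrogen-bond donors and the leaving group has 1. Among these compounds, then, a hydrogen-bond donor on the indole is not required for the lower numbers, and a 1.0-fold higher number from compound 2 to compound 3 (0.02 log units; within the scatter) shows that compound 3, directly attached to the carbonyl carbon, matches compound 2, which keeps that donor and carries a methylene spacer. No measurement available here explains either step.

The compounds shown leave open how much of the step from compound 1 belongs to the methyl and how much to the changed attachment point of the indole. They also leave open whether 1H-indol-3-yl or 1-ethyl-1H-indol-3-yl on the same carbonyl carbon would give a similar number.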